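The source may hold more compounds than are shown below. What is called first, only, known or untested is meant among the compounds shown, and "the series" means these compounds.

Compound 2 `c1ccc(COc2ccc(OCCOCCNC3CCCCC3)cc2)cc1` gives the lowest of the three numbers measured in a functional assay on SK-OV-3 cells (Homo sapiens) for inhibition, read by CCK-8 assay, with a stated time of 70 h; on this read-out lower numbers stand for stronger inhibition and higher numbers for weaker inhibition: in it compound 2 gives 7370 nM. Compound 1 `c1ccc(COc2ccc(OCCOCCNC3CCCC3)cc2)cc1` gives 24800 nM in this assay, and compound 3 `c1ccc(COc2ccc(OCCOCCNC3CCC3)cc2)cc1` gives 25000 nM. The steps among these three concern only the ring on the amine nitrogen: a 3.4-fold lower number from compound 1 to compound 2 (0.53 log units; beyond the scatter), a 3.4-fold higher number from compound 2 to compound 3 (0.53 log units; beyond the scatter), and a 1.0-fold higher number from compound 1 to compound 3 (0.00 log units; within the scatter). Compound 4 `O=[N+]([O-])c1ccccc1COc1ccc(OCCOCCNC2CCCCC2)cc1` differs from compound 2 elsewhere, in that it carries nitro in place of hydrogen on an aromatic carbon. Among the compounds with values here, no measured pair probes a change on the benzyl ring, so none of the three steps bears on this one, and the direction it will take in this assay is unknown; the measured data give no ground for expecting a step beyond the scatter in either direction. On that basis compound 4 is estimated at 7400 nM in this assay, within a wide range of 2000 nM to 27000 nM. This estimate means an expected step of a 1.0-fold higher number from compound 2 to compound 4 (0.00 log units; within the scatter).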

Compound 4, half-maximal inhibitory concentration: 2880 nM
Beside the measured number, compound 4's estimate is 2.6-fold (0.41 log units) above it, and the stated range covers the measured number.
By their numbers in this assay, from the lowest: compound 4; then compound 2; then compounds 1 and 3 (each within the scatter of the next).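

The benzyl ring, which none of the first three compounds varied, proves responsive in this assay: nitro in place of hydrogen on an aromatic carbon, ortho to a large group, gives a 2.6-fold lower number from compound 2 to compound 4 (0.41 log units; beyond the scatter). A change away from the ring on the amine nitrogen can therefore also move the number beyond the scatter, and here it moves towards stronger inhibition. Since compound 4 keeps the cyclohexyl group of compound 2, this is seen with that amine substituent only.

As far as these compounds go, it remains open whether an amine, a nitrile or a methoxy group on the same carbon would do the same, and whether nitro would have a similar effect elsewhere on the ring or alongside cyclopentyl or cyclobutyl on the amine nitrogen. No measurement shown here offers an explanation for this step.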